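The source may hold more compounds than are shown below. What is called first, only, known or untested is meant among the compounds shown, and "the series" means these compounds.

Working notes on the shared core. Compound 1 `N#Cc1cc(F)cc(OC(=O)N2CCC(C(c3ccccc3)c3ccccc3)CC2)c1` in an assay on isolated protein for inhibition of Fatty-acid amide hydrolase 1 (Rattus norvegicus), read by fluorescence (on this read-out lower numbers stand for stronger inhibition and higher numbers for weaker inhibition), gives > 1000 nM, which is a limit of the assay and not a number. Compound 2 `N#Cc1ccnc(OC(=O)N2CCC(C(c3ccccc3)c3ccccc3)CC2)c1` in this assay gives > 1000 nM, also a limit. Compound 3 `N#Cc1cc(O)cc(OC(=O)N2CCC(C(c3ccccc3)c3ccccc3)CC2)c1` in this assay gives > 1000 nM, again a limit. All three values sit at the limit of > 1000 nM in this assay, at which 3 of the 3 values shown sit, so the steps a step that the two limits leave unreadable from compound 1 to compound 2, a step that the two limits leave unreadable from compound 1 to compound 3 and a step that the two limits leave unreadable from compound 2 to compound 3 cannot be sized; compound 3 stands level with the other two at the limit. Compound 4 `N#Cc1cccc(OC(=O)N2CCC(C(c3ccccc3)c3ccccc3)CC2)n1` carries the change (6-cyanopyridin-2-yl in place of 3-cyano-5-hydroxyphenyl on an oxygen next to a carbonyl group). For the measured compounds named here, no measured step bears on this change in a readable way, since every exchange of the group on the oxygen next to the carbonyl so far stayed at the limit. Compound 4 is therefore expected to stay near the limit as well, with an expected step that the limit leaves unreadable from compound 3 to compound 4. The estimate for compound 4 is 2000 nM, within 400 nM to 10000 nM.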

Compound 4, half-maximal inhibitory concentration: > 1000 nM
Compound 4: only a limit was reported; the forecaster's own chance of this, stated with the estimate: 70%; the middle value lies beyond the limit too.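

No step among compound 1, compound 2, compound 3 and compound 4 can be read, because each value is a limit of the assay and not a number: the limit of > 1000 nM in this assay, at which 4 of the 4 values shown sit.

The compounds shown leave open which group on an oxygen next to a carbonyl group, if any, gives a readable value in this assay.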